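Moving a hydroxyl on a hydrazone acyl series

The source may report more compounds than this note shows. Statements on the series, on what has been measured and on what is new or still open speak of the compounds shown alone.

Compound 1 `Cc1c(C(=O)N/N=C\c2cc(O)ccc2O)oc2cccc(O)c12` is a weak inhibitor in a functional assay on PC-3 cells (Homo sapiens) for inhibition (a lower number here means a stronger inhibitor, a higher number a weaker inhibitor), where compound 1 gives 95500 nM. Among the measured compounds shown here, that is the only plain number in this set. Compound 2 `Cc1c(C(=O)N/N=C\c2ccc(C(F)(F)F)cc2)oc2cccc(O)c12` has a value that is a limit of the assay rather than a number: in this assay compound 2 gives >= 40000 nM. The evidence at hand is therefore thin, amounting to a single measured figure and one limit, (the limit of >= 40000 nM in this assay, at which 1 of the 2 values shown sits).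

Compound 3 `Cc1c(C(=O)N/N=C\c2ccc(O)cc2O)oc2cccc(O)c12` has not yet been measured. It differs from compound 1 only in where the hydroxyl groups sit on the outer ring: 2,4-dihydroxyphenyl in place of 2,5-dihydroxyphenyl on a carbon with a double bond to nitrogen. Both compounds keep the same core and the same count of atoms, donors and acceptors.

For the measured compounds named here, with no measured step between compounds that differ in one place, there is nothing here to point in either direction. The expectation is that the step from compound 1 to compound 3 in this assay falls within the usual scatter, a 1.2-fold lower number from compound 1 to compound 3 (0.08 log units; within the scatter). Compound 3 is therefore estimated at 80000 nM, with a range from 25000 nM to 250000 nM.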

Compound 3, half-maximal inhibitory concentration: 14800 nM
Beside the measured number, compound 3's estimate is 5.4-fold (0.73 log units) above it; the measured number lies below the stated range.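

Compound 3 shows that the outer ring is sensitive to where its hydroxyl groups sit: in this assay, the change from 2,5-dihydroxyphenyl to 2,4-dihydroxyphenyl on a carbon with a double bond to nitrogen gives a 6.5-fold lower number from compound 1 to compound 3 (0.81 log units; beyond the scatter) and so moves the number by more than repeat measurements would. The earlier compounds shown here offered one plain number and one limit, with no pair to compare; here the two groups carry the same atoms and the same counts of hydrogen-bond donors and acceptors, so only the arrangement separates compound 1 from compound 3. Nothing measured here says why this arrangement gives the lower number.

A single step cannot say which of the two hydroxyl groups accounts for the change, or whether the same move would have a similar effect on other compounds built on the shared core. From the compounds shown here alone, a methoxy group or an amine in place of either hydroxyl on the 2,4-dihydroxyphenyl ring would show whether the hydroxyl itself is needed, and that remains open.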